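The source may report more compounds than this note shows. Statements on the series, on what has been measured and on what is new or still open speak of the compounds shown alone.

Measured so far, in a physicochemical assay for acid dissociation:
compound 1 `c1ccc(Cc2ccc3c(NCCCNCc4ccco4)ccnc3c2)cc1` gives 9.47
compound 2 `COc1ccc(F)cc1CNCCCNc1ccnc2cc(Cc3ccccc3)ccc12` gives 9.47
compound 3 `COc1cccc(CNCCCNc2ccnc3cc(CC(C)C)ccc23)c1O` gives 9.47

Compound 2 stands level with compounds 1 and 3 at the digits shown; its nearest neighbour is compound 1 and its furthest is compound 3, yet both gaps lie within the scatter. Going by the values given here, the only step between measured compounds, no change at the digits printed from compound 1 to compound 2 (within the scatter), put 5-fluoro-2-methoxyphenyl in place of furan-2-yl on a saturated chain carbon bound to an amine nitrogen and left the acid dissociation constant where it was.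

Compound 4 `COc1ccc(F)cc1CNCCCNc1ccnc2cc(-c3cccc4ccccc34)ccc12` has not yet been measured. It differs from compound 2 in one place: naphthalen-1-yl in place of benzyl on an aromatic carbon. Among the compounds with values here, this change sits on the shared core rather than at the end of the chain, a place that no measured step touches, so no step bears on it directly. Across compounds 1, 2 and 3, different groups at the chain end gave the same reading, which points to a value that hardly moves here either. Compound 4 is therefore expected to give 9.47, between 9.15 and 9.8. The step of no change at the digits printed from compound 2 to compound 4 (within the scatter) is estimated to stay within the scatter.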

Compound 4, acid dissociation constant: 9.47
Compound 4: the middle estimate sits on the measured number at the digits printed; measured number inside the range.
By their numbers in this assay, from the lowest: compounds 1, 2, 3 and 4 (each within the scatter of the next).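

In this assay, going by these compounds alone, the only earlier step changed the group at the end of the chain, so this is the first step that touches the shared core. Placing naphthalen-1-yl instead of benzyl on this aromatic carbon brings in a second six-membered aromatic ring and gives no change at the digits printed from compound 2 to compound 4 (within the scatter), so at this position a larger all-carbon aromatic group leaves the reading level. Nothing available here explains why the reading stays level.

The groups shown at this aromatic carbon all contain only carbon and hydrogen, so it remains open whether an amine or a carboxylic acid there would also leave the reading level. Also open, going by these compounds, is how a longer chain between the core and the far amine nitrogen would read.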